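The compounds below may be only part of what the source reports. "The series", "measured", "known", "first", "only" and "open" are said of these compounds alone.

Of the compounds shown here, two of a shared core have been measured in a functional assay on MCF7 cells (Homo sapiens) for antiproliferative activity, read by MTT assay; on this read-out lower numbers stand for stronger inhibition and higher numbers for weaker inhibition. Compound 1 `NS(=O)(=O)c1cccc(/N=C2\NC(=O)/C(=C3/C(=O)Nc4ccccc43)S2)c1` gives only a limit in this assay, > 200000 nM, and this value is a limit rather than a number (the limit of > 200000 nM in this assay, at which 1 of the 2 values shown sits). Going by the values given here, compound 2 `NS(=O)(=O)c1ccc(/N=C2\NC(=O)/C(=C3/C(=O)Nc4ccc(F)cc43)S2)cc1` gives 20500 nM in this assay, and this is the only number in the set. The other value, that of compound 1, is a limit. Compound 3 `NS(=O)(=O)c1ccc(/N=C2\NC(=O)/C(=C3/C(=O)Nc4ccc([N+](=O)[O-])cc43)S2)cc1` has not yet been measured and differs from compound 2 in one place: nitro in place of fluoro on an aromatic carbon, a nitro in place of fluoro on an aromatic carbon. Among the compounds with values here, no step between two measured compounds is available to lean on, so the size of the effect of this change is uncertain. Compound 3 is expected to stay near compound 2, with a step of a 1.4-fold lower number from compound 2 to compound 3 (0.14 log units; within the scatter) that is not expected to reach beyond the scatter. The estimate for compound 3 in this assay is 15000 nM, with a range from 4000 nM to 60000 nM.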

Compound 3, half-maximal inhibitory concentration: > 200000 nM
Compound 3: no number, only a limit; the forecaster's own chance of this, stated with the estimate: 15%; middle value at least 13-fold (1.12 log units) from the limit.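

In this assay, going by these compounds alone, putting nitro in place of fluoro on this aromatic carbon gives an at least 9.7-fold higher number from compound 2 to compound 3 (0.98 log units; beyond the scatter), the first step in the set between two measured compounds that differ in one place. It shows that the read-out at this position depends on the group carried there, and that this change moves the value beyond the scatter toward weaker inhibition. Compound 3 gives a limit and not a number: the limit of > 200000 nM in this assay, at which 2 of the 3 values shown sit.

The compounds shown leave open whether the same loss would follow with another group on this carbon, such as an amine, a methoxy or a plain hydrogen. On these data alone, with a single step in hand, no trend across groups at this position can be read, and the full size of this step remains unknown.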